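The source may hold more compounds than are shown below. What is called first, only, known or untested is meant among the compounds shown, and "the series" means these compounds.

Measured in a functional assay on cells (Endothelial cell, Bos taurus) for antiproliferative activity; a lower number here means a stronger inhibitor, a higher number a weaker inhibitor:
- compound 1 `COc1ccc(/C=C(/F)c2cc(OC)c(OC)c(OC)c2)cc1O`: 1700 nM
- compound 2 `COc1ccc(/C=C(/F)c2cc(OC)c(OC)c(OC)c2)cc1N`: 2000 nM
- compound 3 `COc1ccc(/C(F)=C\c2cc(OC)c(OC)c(OC)c2)cc1N`: 2100 nM

Compound 2 gives 2000 nM, a number within the scatter of the values for both compound 1 and compound 3, so these compounds cannot be ranked against one another.

The next compound is compound 4 `COc1ccc(/C=C(/F)c2cc(OC)c(OC)c(OC)c2)cc1[N+](=O)[O-]`, which keeps the core of compound 2 but has nitro in place of amino on an aromatic carbon, ortho to a methoxy group and meta to a large group: nitro in place of amino on an aromatic carbon.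

Among the measured compounds shown here, only one measured step bears on this place on the ring: a 1.2-fold higher number from compound 1 to compound 2 (0.07 log units; within the scatter). That exchange of amino in place of hydroxy stays within the scatter, so the numbers show no sensitivity to that particular swap. For the measured compounds named here, it is a limited guide, however, as no measured compound carries nitro here and the data cannot show how this group will behave. A step no larger than the scatter is therefore expected, with a slight lean toward a higher number in this assay and considerable uncertainty in both directions.

The expected change is a 1.5-fold higher number from compound 2 to compound 4 (0.18 log units; within the scatter).

For compound 4 the estimated value is 3000 nM, with an expected range from 900 nM to 9000 nM.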

Compound 4, half-maximal inhibitory concentration: 38400 nM
The estimate for compound 4 lay 13-fold (1.11 log units) below the measured number; measured number above the stated range.
By their numbers in this assay, from the lowest: compounds 1, 2 and 3 (each within the scatter of the next); then compound 4.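

In this assay, this position turns out not to be indifferent to what it carries: nitro in place of amino on the aromatic carbon ortho to a methoxy group gives a 19-fold higher number from compound 2 to compound 4 (1.28 log units; beyond the scatter) and marks compound 4 as a much weaker inhibitor, while nitro in place of hydroxy gives a 23-fold higher number from compound 1 to compound 4 (1.35 log units; beyond the scatter) and points the same way. Hydroxy and amino had stayed within the scatter of each other, so the flat picture from those two groups holds for that pair only and does not extend to nitro, which enters with three heavy atoms and no hydrogen-bond donor where amino had one heavy atom and one donor. Nothing in the available information accounts for the size of this step.

On these data alone, whether the drop belongs to nitro alone or would also appear with other groups at this place stays open, and a nitrile, a carboxylic acid or a simple methyl group would help to settle that. As far as these compounds go, it also remains open whether nitro in place of amino on compound 3 would give a step of similar size.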